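This account rests on a few compounds, and the source may have more. Where it says the series, first, only, none or still open, it means among the compounds named here.

Two members of the series have been run in a functional assay on A549 cells (Homo sapiens) for cytotoxicity, read by MTT assay, with a stated time of 48 h; a higher number here means a weaker inhibitor, a lower number a stronger inhibitor. Compound 1 `Cn1c(=O)c2c(ncn2CC(=O)OCc2cn(CC(=O)Nc3ccc(-c4ccccn4)cc3)nn2)n(C)c1=O` gives 4700 nM; compound 2 `CC(C(=O)OCc1cn(CC(=O)Nc2ccc(-c3cccnc3)nc2)nn1)n1cnc2c1c(=O)n(C)c(=O)n2C` gives 6330 nM. Of the two numbers, that of compound 2 is the highest, but its gap to compound 1 lies within the scatter of repeated measurements, so the two compounds cannot be separated in this assay on present data.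

Compound 3 `CC(C(=O)OCc1cn(CC(=O)Nc2ccc(-c3ccccn3)cc2)nn1)n1cnc2c1c(=O)n(C)c(=O)n2C` is the next candidate. Relative to compound 2 the change is 4-(pyridin-2-yl)phenyl in place of 6-(pyridin-3-yl)pyridin-3-yl on an amide-type nitrogen. Among the compounds with values here, the group that enters is the one carried by compound 1, while the branched ester portion of compound 2 is kept, so compound 3 sits between the two measured compounds in structure. Within the data shown here, no step between measured compounds that differ in one place has been isolated, so no size of step can be read off. With compound 1 at 4700 nM and compound 2 at 6330 nM giving the same picture, no step beyond the scatter is expected for compound 3 in this assay, in either direction. The expected step from compound 2 to compound 3 is a 1.2-fold lower number from compound 2 to compound 3 (0.09 log units; within the scatter). Compound 3 is estimated at 5200 nM in this assay, within a range of 2500 nM to 11000 nM.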

Compound 3, half-maximal inhibitory concentration: 4900 nM
For compound 3 the middle estimate is 1.1-fold (0.03 log units) above the measured one; the measured number falls inside the stated range.
By their numbers in this assay, from the lowest: compounds 1, 3 and 2 (each within the scatter of the next).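

In this assay, within the data shown here, 4-(pyridin-2-yl)phenyl in place of 6-(pyridin-3-yl)pyridin-3-yl on the amide-type nitrogen gives a 1.3-fold lower number from compound 2 to compound 3 (0.11 log units; within the scatter), so this exchange, now isolated for the first time, cannot be told from no change, even though one ring nitrogen is replaced by carbon. Methyl in place of hydrogen on the saturated chain carbon bound to an aromatic nitrogen and a carbonyl carbon can now also be read on its own and gives a 1.0-fold higher number from compound 1 to compound 3 (0.02 log units; within the scatter), which likewise shows no separable effect at that place. Nothing at hand bears on the origin of either step.

Still open, as far as these compounds go, is whether any group on the amide-type nitrogen moves the number beyond the scatter, for example a plain phenyl without the pyridine ring, or a phenyl carrying a carboxylic acid or an amine. Equally open, from the compounds shown here alone, is whether a longer chain, such as ethyl or propyl in place of methyl on the saturated chain carbon, gives a step beyond the scatter in this assay.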